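Replacing a pyridine arm with a cyclic sulfone amine

A few compounds are considered here, and "the series" means these few. Any claim that something is new, unique, unknown or untested is made for them only; others in the source may bear on it.

Compound 1 `c1ccc2c(c1)CN[C@@H](CN(CCCCNCc1ccncc1)[C@H]1CCCc3cccnc31)C2` carries a pyridin-4-yl)methyl group on its outer amine nitrogen. In a functional assay on cells for antagonist activity at C-X-C chemokine receptor type 4 (Homo sapiens), read by fluorescence and calcium flux, with stated times of 25 min and 90 s (on this read-out lower numbers stand for stronger inhibition and higher numbers for weaker inhibition), compound 1 gives 22.7 nM, the lowest of the three measured numbers. Compound 2 `c1ccc2c(c1)CN[C@@H](CN(CCCCNCC1CCCCC1)[C@H]1CCCc3cccnc31)C2` gives 158 nM and compound 3 `c1ccc2c(c1)CN[C@@H](CN(CCCCNC1CCSCC1)[C@H]1CCCc3cccnc31)C2` gives 54.7 nM. The step of a 7.0-fold higher number from compound 1 to compound 2 (0.84 log units; beyond the scatter) and the step of a 2.4-fold higher number from compound 1 to compound 3 (0.38 log units; beyond the scatter) both show that moving away from the pyridine arm weakens inhibition, while a 2.9-fold lower number from compound 2 to compound 3 (0.46 log units; beyond the scatter) shows a saturated ring with a hetero atom faring better than one without. Compound 4 `O=S1(=O)CCC(NCCCCN(C[C@H]2Cc3ccccc3CN2)[C@H]2CCCc3cccnc32)CC1` differs from compound 1 as 1,1-dioxothian-4-yl in place of (pyridin-4-yl)methyl on an amine nitrogen. Since compound 3 already carries the sulfur ring, a modest weakening is expected, a 2.2-fold higher number from compound 1 to compound 4 (0.34 log units; beyond the scatter), giving an estimate for compound 4 of 50 nM, within 20 nM to 130 nM.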

Compound 4, half-maximal inhibitory concentration: 45.5 nM
Compound 4: middle estimate off by 1.1-fold (0.04 log units), on the high side, and the stated range covers the measured number.
By their numbers in this assay, from the lowest: compounds 1, 4 and 3 (each within the scatter of the next, the first and the last beyond it); then compound 2.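

At this amine nitrogen, 1,1-dioxothian-4-yl can stand in for (pyridin-4-yl)methyl without a clear loss (a 2.0-fold higher number from compound 1 to compound 4 (0.30 log units; within the scatter)), so an aromatic ring is not required here to stay in this range. Adding the two oxygens to the sulfur ring makes no clear difference (a 1.2-fold lower number from compound 3 to compound 4 (0.08 log units; within the scatter)), whereas the gain over cyclohexylmethyl is clear (a 3.5-fold lower number from compound 2 to compound 4 (0.54 log units; beyond the scatter)).

As far as these compounds go, whether a piperidin-4-yl ring, with nitrogen as its hetero atom, or a tetrahydropyran-4-yl ring, with oxygen, would fit as well remains open. Nothing available here explains these differences.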